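Triazole N-substituent swap in a HeLa cytotoxicity series

A few compounds are considered here, and "the series" means these few. Any claim that something is new, unique, unknown or untested is made for them only; others in the source may bear on it.

Compound 1 `COC(=O)[C@@H]1CCCN1C(=O)CCC(=O)Oc1ccc(C[C@H]2C(=O)OC[C@@H]2Cc2ccc(OC)c(OC)c2)cc1OC` gives 145000 nM in an ADME assay on HeLa cells (Homo sapiens) for cytotoxicity, read by MTT assay; a lower number here means a stronger inhibitor, a higher number a weaker inhibitor. Compound 2 `COc1ccc(C[C@H]2COC(=O)[C@@H]2Cc2ccc(OCc3cn(-c4ccc(Br)cc4)nn3)c(OC)c2)cc1OC` gives 128000 nM in this assay, a number that sits within the scatter of compound 1, so the two cannot be ordered. Compound 3 `COc1ccc(C[C@H]2COC(=O)[C@@H]2Cc2ccc(OCc3cn(Cc4ccccc4)nn3)c(OC)c2)cc1OC` is not yet measured in this assay; it differs from compound 2 by benzyl in place of 4-bromophenyl on an aromatic nitrogen. Among the measured compounds shown here, no measured pair shows this change, so no step beyond the scatter is expected in either direction. Compound 3 is estimated at 130000 nM, ranging from 60000 nM to 280000 nM, an expected step of a 1.0-fold higher number from compound 2 to compound 3 (0.01 log units; within the scatter).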

Compound 3, half-maximal inhibitory concentration: 346000 nM
Estimate against measurement, compound 3: 2.7-fold (0.43 log units) below; measured number above the stated range.
By their numbers in this assay, from the lowest: compounds 2 and 1 (each within the scatter of the next); then compound 3.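

In this assay, among the compounds shown here, benzyl in place of 4-bromophenyl on an aromatic nitrogen gives a 2.7-fold higher number from compound 2 to compound 3 (0.43 log units; beyond the scatter) and so provides the first step beyond the scatter at this position. The number moves although both groups carry one six-membered aromatic ring of carbon only and neither has hydrogen-bond donors or acceptors. Nothing available explains the step. 

On these data alone, the swap changes the bromine and the ring's attachment together, so the contribution of each stays open. Unsubstituted phenyl and 4-bromobenzyl would separate them, and an aminomethyl or carboxylic acid group on the ring remains open too.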